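The compounds below may be only part of what the source reports. "The series", "measured", "known", "first", "only" and "open" are said of these compounds alone.

Measured so far in a functional assay (Homo sapiens) for antiproliferative activity; on this read-out lower numbers stand for stronger inhibition of growth and higher numbers for weaker inhibition of growth: compound 1 `Cc1cn2c(/C=N/NC(=N)N)c(-c3ccncc3)nc2s1`, 28200 nM; compound 2 `Cc1sc2nc(-c3ccncc3)c(/C=N/NC(=N)N)n2c1C`, 95500 nM; compound 3 `Cc1cn2c(/C=N/NC(=N)N)c(-c3cccnc3)nc2s1`, 51300 nM.

Compound 2 stands at the high end of the three: its gap to compound 3 is within the scatter, whereas a 3.4-fold higher number from compound 1 to compound 2 (0.53 log units; beyond the scatter) lies beyond it. Compound 4 `Cc1sc2nc(-c3ccccn3)c(/C=N/NC(=N)N)n2c1C` differs from compound 2 in one place: pyridin-2-yl in place of pyridin-4-yl on an aromatic carbon. For the measured compounds named here, the only measured step that also swaps one pyridyl isomer for another is a 1.8-fold higher number from compound 1 to compound 3 (0.26 log units; within the scatter), which stayed within the scatter; the methyl step is unrelated to this change. For compound 4, therefore, no step beyond the scatter in this assay is expected, with at most a slight lean toward a higher number. Compound 4 is estimated at 140000 nM, range 55000 nM to 350000 nM, which corresponds to an expected 1.5-fold higher number from compound 2 to compound 4 (0.17 log units; within the scatter).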

Compound 4, concentration for total growth inhibition: 83200 nM
Compound 4: the middle estimate sits 1.7-fold (0.23 log units) above what was measured; the range from low to high includes it.
By their numbers in this assay, from the lowest: compounds 1, 3, 4 and 2 (each within the scatter of the next, the first and the last beyond it).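

In this assay, pyridin-2-yl in place of pyridin-4-yl on this aromatic carbon, next to the ring nitrogen, gives a 1.1-fold lower number from compound 2 to compound 4 (0.06 log units; within the scatter) and stays within the scatter. The other pyridyl swap, a 1.8-fold higher number from compound 1 to compound 3 (0.26 log units; within the scatter), also stays within it, so both swaps shown, each on its own core, fall within the scatter. No measurement shown offers an explanation for this result.

Still open, on these data alone, is whether phenyl or an aminomethyl group on this carbon would give a step beyond the scatter. Also open, as far as these compounds go, is how pyridin-3-yl reads on the core of compound 2.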